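Swapping a three-atom sulfur group for methylsulfonyl

The compounds below may be only part of what the source reports. "The series", "measured", "known", "first", "only" and "open" are said of these compounds alone.

Measured so far in a functional assay on the whole organism for antagonist activity, with Mus musculus as the target; a lower number here means that less compound is needed, a higher number that more compound is needed for the effect:
Compound 1 `Cn1c(-c2cccs2)nnc1[S+](C)[O-]` gives > 200 mg/kg, which is a limit of the assay and not a number.
Compound 2 `Cn1c(-c2cccs2)nnc1S(C)(=O)=O` gives > 200 mg/kg, also a limit.
Compound 3 `Cn1c(-c2ccccc2)nnc1[S+](C)[O-]` gives > 100 mg/kg, again a limit.

From compound 1 to compound 2 the change is a group of 4 heavy atoms (1 carbon, 2 oxygen, 1 sulfur; no ring) in place of a group of 3 heavy atoms (1 carbon, 1 oxygen, 1 sulfur; no ring), on an aromatic carbon. The resulting step that the two limits leave unreadable from compound 1 to compound 2 cannot be read because both ends sit at the limit of > 200 mg/kg in this assay, at which 2 of the 3 values shown sit.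

Compound 4 `Cn1c(-c2ccccc2)nnc1S(C)(=O)=O` has not been measured. It differs from compound 3 by a group of 4 heavy atoms (1 carbon, 2 oxygen, 1 sulfur; no ring) in place of a group of 3 heavy atoms (1 carbon, 1 oxygen, 1 sulfur; no ring), on an aromatic carbon, the same kind of change. How the core of compound 3 differs from the core of compound 1 is not broken down here.

The step from compound 3 to compound 4 is expected to be a step that the limit leaves unreadable from compound 3 to compound 4 in this assay, which rests on compound 3 sitting at the limit of > 100 mg/kg in this assay, at which 1 of the 3 values shown sits, and on the unreadable step that the two limits leave unreadable from compound 1 to compound 2. Compound 4 is therefore estimated near 200 mg/kg, between 100 mg/kg and 600 mg/kg, most likely reported only as a limit.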

Compound 4, dose for half-maximal effect: > 200 mg/kg
Compound 4: no number, only a limit; the forecaster's own chance of this, stated with the estimate: 90%; the middle value sits exactly at the limit.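

Compound 3 and compound 4 both give only limits of the assay, not numbers, so the step between them cannot be read. Whether methylsulfonyl changes the dose needed at all stays open across the compounds shown.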